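Chain-lengthened phenoxyalkoxy benzofuran amidines and L6 cytotoxicity

The source may hold more compounds than are shown below. What is called first, only, known or untested is meant among the compounds shown, and "the series" means these compounds.

Measured so far:
Compound 1, `N=C(N)c1ccc2cc(-c3cccc(OCCCCOc4ccccc4)c3)oc2c1`: 7600 nM
Compound 2, `N=C(N)c1ccc2cc(-c3cccc(OCCCCCOc4ccccc4)c3)oc2c1`: 4100 nM
Compound 3, `N=C(N)c1ccc2oc(-c3ccc(OCCCCCOc4ccccc4)cc3)cc2c1`: 4200 nM

Three amidine-bearing compounds have been tested in an ADME assay on L6 cells (Rattus norvegicus) for cytotoxicity, read by resazurin assay, with a stated time of 70 h; a higher number here means a weaker inhibitor, a lower number a stronger inhibitor. Compound 1 gives 7600 nM in this assay, compound 2 gives 4100 nM, and compound 3 gives 4200 nM. Compound 2 arises from compound 1 through one change, (phenoxymethyl in place of phenoxy on a saturated chain carbon, four bonds along the chain from an oxygen on an aromatic ring), and the step was a 1.9-fold lower number from compound 1 to compound 2 (0.27 log units; within the scatter). Compound 3 is built on a different core from compound 1; the difference between the two cores is not broken down here, and their two values lie close together.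

Compound 4, `N=C(N)c1ccc2oc(-c3ccc(OCCCCCCOc4ccccc4)cc3)cc2c1`, has not yet been measured in this assay. It is related to compound 3 by phenoxymethyl in place of phenoxy on a saturated chain carbon, five bonds along the chain from an oxygen on an aromatic ring. This is the same kind of change as that from compound 1 to compound 2, but the place differs: in the earlier pair it sits four bonds along the chain from an oxygen on an aromatic ring, whereas here it sits five bonds along the chain from an oxygen on an aromatic ring. Because a 1.9-fold lower number from compound 1 to compound 2 (0.27 log units; within the scatter) stayed within the scatter, a step of similar small size is expected here, a 1.4-fold lower number from compound 3 to compound 4 (0.15 log units; within the scatter). On that basis compound 4 is estimated at 3000 nM, with a likely range from 1500 nM to 7000 nM.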

Compound 4, half-maximal inhibitory concentration: 3300 nM
Compound 4: middle estimate off by 1.1-fold (0.04 log units), on the low side, within the range that was stated.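

In this assay, the replacement of phenoxy by phenoxymethyl on the core of compound 3 gave a 1.3-fold lower number from compound 3 to compound 4 (0.10 log units; within the scatter), and this step does not stand apart from the earlier one on the core of compound 1: the same change on two cores in this assay, a 1.9-fold lower number (0.27 log units; within the scatter) from compound 1 to compound 2 and a 1.3-fold lower number (0.10 log units; within the scatter) from compound 3 to compound 4, 1.5-fold (0.16 log units) apart, within the scatter of two such steps Within these two pairs, then, the change behaved alike on both cores, and nothing in the numbers suggests that the core altered its result, even though the change sits four bonds along the chain from an oxygen on an aromatic ring in one pair and five bonds along in the other. This does not show that the change truly lowers the number, as neither step lies beyond the scatter, and two small steps on two cores cannot establish that it would carry over in the same way to any other core in the series.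

The compounds shown leave open what a longer chain than that of compound 4 would give on either core, and whether the small steps would persist at such lengths. They also leave open how the series would read with a nitrile or a fluorine on the phenoxy ring, or with a carboxylic acid or an amine in place of the amidine.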